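Removing the Methoxy from a Biaryl Amide Inhibitor

The source may hold more compounds than are shown below. What is called first, only, known or untested is meant among the compounds shown, and "the series" means these compounds.

Compound 1, `Cc1ccc(C(=O)N2CCC(O)(Cc3ccccc3)CC2)c(-c2ccncc2)c1`; in an assay for inhibition of cholesterol 24-hydroxylase (Homo sapiens), using NADPH, with stated times of 15 min and 5 min (on this read-out higher numbers stand for weaker inhibition and lower numbers for stronger inhibition), compound 1 gives 4.4 nM.
Compound 2, `O=C(c1cc(Cl)ccc1-c1ccncc1)N1CCC(O)(Cc2ccccc2)CC1`; in this assay compound 2 gives 2.4 nM.
Compound 3, `COc1ccc(-c2ccncc2)c(C(=O)N2CCC(O)(Cc3ccccc3)CC2)c1`; in this assay compound 3 gives 4.7 nM.

Compound 3 carries the highest of the three numbers, but none of the gaps is beyond the scatter: compound 1 sits closest to it, and the step of a 2.0-fold higher number from compound 2 to compound 3 (0.29 log units; within the scatter) is the widest gap seen, still within the scatter. The three substituents on the aromatic ring of the shared core thus give numbers that cannot be told apart.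

Compound 4, `O=C(c1ccccc1-c1ccncc1)N1CCC(O)(Cc2ccccc2)CC1`, differs from compound 3 in one place: hydrogen in place of methoxy on an aromatic carbon. Among the measured compounds shown here, no measured step removes a substituent outright; the only step that bears on this position is the exchange of methoxy for chloro, a 2.0-fold higher number from compound 2 to compound 3 (0.29 log units; within the scatter), which stayed within the scatter. Since the three substituents gave indistinguishable numbers, the bare ring is expected to behave in the same way, with the step of a 1.2-fold lower number from compound 3 to compound 4 (0.07 log units; within the scatter) not expected to go beyond the scatter. Compound 4 is therefore estimated at 4 nM, between 1.5 nM and 11 nM.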

Compound 4, half-maximal inhibitory concentration: 7.9 nM
For compound 4 the middle estimate is 2.0-fold (0.30 log units) below the measured one, and the stated range covers the measured number.
By their numbers in this assay, from the lowest: compounds 2, 1, 3 and 4 (each within the scatter of the next, the first and the last beyond it).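

Among the compounds shown here, removing the substituent altogether gives the first reading of this carbon, meta to a large group and para to a pyridin-4-yl group, with only hydrogen on it. In this assay, hydrogen cannot be told apart from methoxy (a 1.7-fold higher number from compound 3 to compound 4 (0.23 log units; within the scatter)) or from methyl (a 1.8-fold higher number from compound 1 to compound 4 (0.25 log units; within the scatter)), but it does separate from chloro, modestly (a 3.3-fold higher number from compound 2 to compound 4 (0.52 log units; beyond the scatter)). So among the groups shown, chloro is the only one whose loss moves the number beyond the scatter, and nothing available here accounts for that difference.

The compounds shown leave open whether a bromine atom, a nitrile, an amine or a carboxylic acid on this carbon would stay as close to hydrogen as methoxy and methyl do. They also leave open whether the step from chloro to hydrogen would be the same size on other carbons of this ring.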